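The source may report more compounds than this note shows. Statements on the series, on what has been measured and on what is new or still open speak of the compounds shown alone.

Compound 1 `CN(C)C(=O)/C=C/c1ccc2noc(-c3ccccc3)c2c1` reaches only the assay limit of > 100000 nM in an assay for inhibition of inositol hexakisphosphate kinase 3 (Homo sapiens), read by colorimetric assay, coupled enzyme assay and malachite green, with a stated time of 120 min, in the presence of a further agent that is not named here (a lower number here means a stronger inhibitor, a higher number a weaker inhibitor), a limit rather than a number (the limit of > 100000 nM in this assay, at which 1 of the 2 values shown sits). For the measured compounds named here, compound 2 `O=C(O)c1ccc2noc(-c3ccc(Oc4ccccn4)cc3)c2c1` gives 2060 nM in this assay, the single number on record here. Compound 3 `O=C(O)c1ccc2noc(-c3ccc(N4CCCC4=O)cc3)c2c1` carries 2-oxopyrrolidin-1-yl in place of (pyridin-2-yl)oxy on an aromatic carbon. Going by the values given here, no step between two measured compounds covers this change, so the step of a 2.4-fold higher number from compound 2 to compound 3 (0.39 log units; beyond the scatter) is expected to be a moderate loss, somewhat beyond the scatter. From compound 2 at 2060 nM, compound 3 is estimated at 5000 nM, within 1200 nM to 25000 nM in this assay.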

Compound 3, half-maximal inhibitory concentration: 2170 nM
The estimate for compound 3 lay 2.3-fold (0.36 log units) above the measured number; measured number inside the range.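

Exchanging (pyridin-2-yl)oxy for 2-oxopyrrolidin-1-yl on the aromatic carbon para to a large group gives a 1.1-fold higher number from compound 2 to compound 3 (0.02 log units; within the scatter) in this assay. This position therefore accepts a five-membered non-aromatic ring as well as the six-membered aromatic ring with its ether link, with no separation between the two groups in this read-out. Nothing on record gives a reason for this match.

Open: how a morpholine, a dimethylamino group or a plain phenyl ring at this position would compare, and whether any group here can move the number beyond the scatter.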